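Chloromethyl in place of prop-1-en-1-yl on compound 2

A few compounds are considered here, and "the series" means these few. Any claim that something is new, unique, unknown or untested is made for them only; others in the source may bear on it.

- compound 1 `O=C(O)c1cc(-c2ccc(Oc3ccccc3)cc2)nn1C1CCCN(C(=O)CCl)C1`: 400 nM
- compound 2 `C/C=C/C(=O)N1CCCC(n2nc(-c3ccc(Oc4ccccc4)cc3)cc2C(=O)OCC)C1`: 19600 nM
- compound 3 `C/C=C/C(=O)N1CCCC(n2nc(-c3ccc(Oc4ccccc4)cc3)cc2C(=O)O)C1`: > 60000 nM (a limit of the assay, not a number)

These values come from a functional assay on Maver1 cells (Homo sapiens) for inhibition, read by luminescence and CellTiter-Glo, with a stated time of 72 h; a higher number here means a weaker inhibitor, a lower number a stronger inhibitor. Compound 2 has the higher of the two actual numbers, and the other, from compound 1, lies well below it. For compound 3 the assay reports only a limit.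

Compound 4 `CCOC(=O)c1cc(-c2ccc(Oc3ccccc3)cc2)nn1C1CCCN(C(=O)CCl)C1` differs from compound 2 in one place: chloromethyl in place of prop-1-en-1-yl on a carbonyl carbon. In words, chloromethyl stands in place of prop-1-en-1-yl on a carbonyl carbon whose other neighbour is an amide-type nitrogen in a ring.

The same exchange, in the opposite direction, has been measured once, and it is a large step: an at least 150-fold higher number from compound 1 to compound 3 (2.17 log units; beyond the scatter). Those two compounds lack the ethyl group that compound 2 and compound 4 carry. That second difference gave a smaller step: an at least 3.0-fold higher number from compound 2 to compound 3 (0.48 log units; beyond the scatter). Among the compounds with values here, both steps end at the limit, so their true sizes remain open, and no measurement yet shows that the first carries over to the ethyl compounds.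

A large fall in the number is nevertheless expected in this assay, and the estimated change is a 150-fold lower number from compound 2 to compound 4 (2.18 log units; beyond the scatter). Compound 4 is expected at 130 nM, with an estimated range of 30 nM to 600 nM.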

Compound 4, half-maximal inhibitory concentration: 1200 nM
For compound 4 the middle estimate is 9.2-fold (0.97 log units) below the measured one; the measured number lies above the stated range.
By their numbers in this assay, from the lowest: compound 1; then compound 4; then compound 2. At a limit, above all of these: compound 3.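

Measured on the ethyl compounds in this assay, chloromethyl in place of prop-1-en-1-yl on the carbonyl carbon gives a 16-fold lower number from compound 2 to compound 4 (1.21 log units; beyond the scatter), and with chloromethyl held fixed, ethyl in place of hydrogen on the oxygen next to the carbonyl group gives a 3.0-fold higher number from compound 1 to compound 4 (0.48 log units; beyond the scatter). The exchange on the carbonyl carbon therefore lowers the number on both cores, but its size depends on whether the ethyl group is present: the same change on two cores in this assay, an at least 150-fold higher number (2.17 log units; beyond the scatter) from compound 1 to compound 3 and a 16-fold higher number (1.21 log units; beyond the scatter) from compound 4 to compound 2, at least 9.1-fold (0.96 log units) apart, beyond the scatter of two such steps The ethyl change goes further and reverses direction, since removing the ethyl group raises the number with prop-1-en-1-yl and lowers it with chloromethyl: the same change on two cores in this assay, an at least 3.0-fold higher number (0.48 log units; beyond the scatter) from compound 2 to compound 3 and a 3.0-fold lower number (0.48 log units; beyond the scatter) from compound 4 to compound 1, at least 9.1-fold (0.96 log units) apart, beyond the scatter of two such steps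

Going by these compounds, compound 3 is reported only as a limit, > 60000 nM, so the true size of both gaps between steps stays open. The compounds shown also leave open how a longer chain on that oxygen, such as propyl, or a bromomethyl group on the carbonyl carbon would read in this assay.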